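A longer chain and a lower number?

A few compounds are considered here, and "the series" means these few. Any claim that something is new, unique, unknown or untested is made for them only; others in the source may bear on it.

Measured in a functional assay on brain (Rattus norvegicus, strain Wistar) for inhibition; on this read-out higher numbers stand for weaker inhibition and lower numbers for stronger inhibition:
Compound 1 `CCCCCCCCc1ccc(-c2c(C)[nH]c(=O)n2C)cc1`: 19400 nM
Compound 2 `CCCCCCCCCCc1ccc(-c2c(C)[nH]c(=O)n2C)cc1`: 7900 nM

Compound 2 stands lowest of the two measured compounds, at 7900 nM, and so is the stronger inhibitor. The next compound, compound 3 `CCCCCCCCCCCCc1ccc(-c2c(C)[nH]c(=O)n2C)cc1`, differs from it by ethyl in place of hydrogen on a saturated chain carbon, ten or more bonds along the chain from an aromatic carbon. Among the compounds with values here, only one measured step bears on this change. The same replacement, made eight bonds along the chain, gave a 2.5-fold lower number from compound 1 to compound 2 (0.39 log units; beyond the scatter), a modest change beyond the scatter. One step cannot show whether the trend continues, so a similar modest drop is expected, with wide uncertainty. The expected step is a 2.4-fold lower number from compound 2 to compound 3 (0.38 log units; beyond the scatter). Compound 3 is estimated at 3300 nM, with an expected range of 1200 nM to 9500 nM.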

Compound 3, half-maximal inhibitory concentration: 13000 nM
Estimate against measurement, compound 3: 3.9-fold (0.60 log units) below; the measured number lies above the stated range.
By their numbers in this assay, from the lowest: compounds 2, 3 and 1 (each within the scatter of the next, the first and the last beyond it).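

In this assay, the gain seen on first lengthening the chain does not carry on at this position: ethyl in place of hydrogen on a saturated chain carbon gives a 1.6-fold higher number from compound 2 to compound 3 (0.22 log units; within the scatter), so compound 3 cannot be told apart from compound 2. Butyl in place of hydrogen, eight bonds along the chain, gives a 1.5-fold lower number from compound 1 to compound 3 (0.17 log units; within the scatter), so compound 3 cannot be told apart from compound 1 either, although compound 1 and compound 2 remain separated by more than the scatter. Nothing available explains why the earlier drop did not continue.

From the compounds shown here alone, whether a still longer chain would remain level with compound 3 or move away from it stays open. So does how a carboxylic acid or an amine on the chain would alter the number.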